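Working notes: aryl amine series, cytotoxicity on BT-549 cells

A few compounds are considered here, and "the series" means these few. Any claim that something is new, unique, unknown or untested is made for them only; others in the source may bear on it.

Measured compounds:
- Compound 1 `O=C1CNc2nc(Nc3ccc(F)cc3)ncc2N1` — in a functional assay on BT-549 cells (Homo sapiens) for cytotoxicity, read by MTT assay, with a stated time of 48 h (a higher number here means a weaker inhibitor, a lower number a stronger inhibitor), compound 1 gives 92400 nM
- Compound 2 `O=C1CNc2nc(Nc3ccc(Cl)cc3)ncc2N1` — in this assay compound 2 gives 17700 nM
- Compound 3 `COc1ccc(Nc2ncc3c(n2)NCC(=O)N3)cc1` — in this assay compound 3 gives 95000 nM

Compound 2 stands lowest of the three in this assay; the steps of a 5.2-fold lower number from compound 1 to compound 2 (0.72 log units; beyond the scatter) and a 5.4-fold higher number from compound 2 to compound 3 (0.73 log units; beyond the scatter) both lie beyond the scatter, so compound 2 is the strongest of the measured set. Compounds 1 and 3 sit within the scatter of each other, as a 1.0-fold higher number from compound 1 to compound 3 (0.01 log units; within the scatter) shows, and no order between them is claimed.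

The next compound, compound 4 `CN1CC(=O)Nc2cnc(Nc3ccc(Cl)cc3)nc21`, keeps the chloro substituent of compound 2 and differs from it in one place: methyl in place of hydrogen on a nitrogen on an aromatic ring in a ring.

For the measured compounds named here, none of the measured steps touches this position; all three alter only the aromatic substituent. Going by the values given here, there is therefore no step in this assay that bears on a change at the ring nitrogen. Among the compounds with values here, the only guide is that the chloro compound 2 is the strongest point in this assay, and the shared core is otherwise unchanged. The expectation for compound 4 is a step of no size beyond the scatter, with the wider uncertainty that comes from an untested position. Compound 4 is expected to give about 25000 nM in this assay, within the range 8000 nM to 80000 nM, which is the estimated step of a 1.4-fold higher number from compound 2 to compound 4 (0.15 log units; within the scatter).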

Compound 4, half-maximal inhibitory concentration: 91100 nM
The estimate for compound 4 lay 3.6-fold (0.56 log units) below the measured number, and the stated range ends below it.
By their numbers in this assay, from the lowest: compound 2; then compounds 4, 1 and 3 (each within the scatter of the next).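

In this assay, for the compounds shown here, methyl in place of hydrogen on a nitrogen on an aromatic ring in a ring gives a 5.1-fold higher number from compound 2 to compound 4 (0.71 log units; beyond the scatter), the first step read at this position, since the earlier steps altered only the aromatic substituent. The chloro substituent stays fixed across this step, so the lower number of compound 2 is not carried over to its methyl counterpart, and this ring nitrogen is shown not to be indifferent to a single added carbon. Nothing available bears on the reason for the rise, so the step stands as an observation only.

The compounds shown leave open whether the step depends on the size or nature of the group on this nitrogen, as an ethyl group, a longer chain ending in an amine, or a chain carrying a carboxylic acid could show. They also leave open whether the same methyl change raises the number to a similar extent when the chloro substituent is replaced by the fluoro group of compound 1 or the methoxy group of compound 3.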